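Stomach inhibition series: step from compound 3 to compound 4

A few compounds are considered here, and "the series" means these few. Any claim that something is new, unique, unknown or untested is made for them only; others in the source may bear on it.

Measured so far in a functional assay on the whole organism (stomach) for inhibition, with Rattus norvegicus as the target, at a dose of 100 mg/kg by the intraduodenal route; on this read-out lower numbers stand for less inhibition and higher numbers for more inhibition at the one dose given (going by the name of the read-out):
compound 1 `N#CCCn1nc(-c2ccccc2)ccc1=O` gives 10.1%
compound 2 `CNC(=O)CCn1nc(-c2ccccc2)ccc1=O` gives 3.5%
compound 3 `NC(=O)CCn1nc(-c2ccccc2)ccc1=O` gives -2.8%

Compound 3 stands lowest of the three numbers; the gap to compound 2 is within the scatter, a number 6.3 percentage points lower from compound 2 to compound 3 (within the scatter), while the gap to compound 1 is beyond it, a number 12.9 percentage points lower from compound 1 to compound 3 (beyond the scatter). Compound 4 `C/N=C(/S)CCCCCn1nc(-c2ccccc2)ccc1=O` differs from compound 3 by a group of 7 heavy atoms (5 carbon, 1 nitrogen, 1 sulfur; no ring) in place of a group of 3 heavy atoms (1 carbon, 1 nitrogen, 1 oxygen; no ring), on a saturated chain carbon, two bonds along the chain from an aromatic nitrogen. Among the measured compounds shown here, no measured step touches the entering group. The steps at the same chain carbon are a number 6.6 percentage points lower from compound 1 to compound 2 (within the scatter) and a number 12.9 percentage points lower from compound 1 to compound 3 (beyond the scatter), both exchanges of cyano, and all three measured numbers sit low. With nothing to anchor the new group, the expected step of a number 10.8 percentage points higher from compound 3 to compound 4 (beyond the scatter) in this assay is small, if anything upward toward the level of compound 1. Compound 4 is estimated at 8%, range -8% to 28%.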

Compound 4, a percentage reported as inhibition, in the whole organism at one dose (the size of the read-out at that dose, not a potency): 92.3%
Compound 4: the middle estimate sits 84.3 percentage points below what was measured; the measured number lies above the stated range.
By their numbers in this assay, from the lowest: compounds 3, 2 and 1 (each within the scatter of the next, the first and the last beyond it); then compound 4.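

In this assay this position, a saturated chain carbon two bonds along the chain from an aromatic nitrogen, proves able to carry a large change: the group of 7 heavy atoms gives a number 95.1 percentage points higher from compound 3 to compound 4 (beyond the scatter) and a number 88.8 percentage points higher from compound 2 to compound 4 (beyond the scatter) and a number 82.2 percentage points higher from compound 1 to compound 4 (beyond the scatter) in the same read-out. The exchanges among cyano, methylcarbamoyl and carbamoyl moved the number modestly at most, so the high range appears only with this group. No available evidence bears on the reason for the rise.

The entering group differs from carbamoyl in both chain length and its sulfur-bearing end, and the compounds shown do not separate the two. A longer chain ending in carbamoyl, or in an amine or a carboxylic acid, would address this.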